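Chloro in place of methyl: compound 3 to compound 4

The source may hold more compounds than are shown below. What is called first, only, known or untested is meant among the compounds shown, and "the series" means these compounds.

Three members of the series have been run in a functional assay on RCC4 cells (Homo sapiens) for antiproliferative activity, read by XTT assay, with a stated time of 48 h; a lower number here means a stronger inhibitor, a higher number a weaker inhibitor. Compound 1 `CCS(=O)(=O)N(Cc1cn([C@@H]2O[C@H](COC(C)=O)[C@@H](OC(C)=O)[C@H](OC(C)=O)[C@H]2OC(C)=O)nn1)c1ccccc1` gives 175000 nM in this assay. Compound 2 `CCS(=O)(=O)N(Cc1cn([C@@H]2O[C@H](COC(C)=O)[C@@H](OC(C)=O)[C@H](OC(C)=O)[C@H]2OC(C)=O)nn1)c1ccc(Cl)cc1` reaches only the limit of this assay, > 250000 nM, so no number is available for it. Compound 3 `CC(=O)OC[C@H]1O[C@@H](n2cc(CN(c3ccc(C)cc3)S(=O)(=O)c3ccccc3)nn2)[C@H](OC(C)=O)[C@@H](OC(C)=O)[C@@H]1OC(C)=O` gives 130000 nM in this assay; of the two numbers shown it is the lower one, but its gap to compound 1 lies within the scatter, so the two cannot be told apart. Compound 4 `CC(=O)OC[C@H]1O[C@@H](n2cc(CN(c3ccc(Cl)cc3)S(=O)(=O)c3ccccc3)nn2)[C@H](OC(C)=O)[C@@H](OC(C)=O)[C@@H]1OC(C)=O` is still to be measured.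

Compound 4 differs from compound 3 by chloro in place of methyl on an aromatic carbon, para to a large group; cut one bond further out, 4-methylphenyl becomes 4-chlorophenyl.

For the measured compounds named here, the only measured step at a comparable place is an at least 1.4-fold higher number from compound 1 to compound 2 (0.15 log units; that floor lies within the scatter), which ended at the limit of > 250000 nM in this assay, at which 1 of the 3 values shown sits, and whose floor lies within the scatter. Putting chloro onto that carbon therefore did not lower the number, and exchanging methyl for chloro is expected to move the number little, if anything upward. For compound 4 the estimate in this assay is 180000 nM, with a range from 80000 nM to 400000 nM. This corresponds to an expected step of a 1.4-fold higher number from compound 3 to compound 4 (0.14 log units; within the scatter), which stays within the scatter, until the measurement shows otherwise.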

Compound 4, half-maximal inhibitory concentration: 115000 nM
Estimate against measurement, compound 4: 1.6-fold (0.19 log units) above, and the stated range covers the measured number.
By their numbers in this assay, from the lowest: compounds 4, 3 and 1 (each within the scatter of the next). At a limit, above all of these: compound 2.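

In this assay, exchanging methyl for chloro on this aromatic carbon, with phenyl on the sulfonyl sulfur, gives no change that can be told from the scatter: a 1.1-fold lower number from compound 3 to compound 4 (0.05 log units; within the scatter). For the compounds shown here, the 4-chlorophenyl group therefore does not by itself place a compound at the top of the series, since with that group kept, phenyl in place of ethyl on the sulfonyl sulfur gives an at least 2.1-fold lower number from compound 2 to compound 4 (0.33 log units; beyond the scatter), the first step here that lies beyond the scatter and the first sign that the sulfonyl substituent matters. The size of that step is only a floor, since compound 2 is a limit and not a number: the limit of > 250000 nM in this assay, at which 1 of the 4 values shown sits.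

The compounds shown leave open whether phenyl in place of ethyl on the sulfonyl sulfur gives a comparable step when the other aromatic ring carries hydrogen or methyl instead of chloro. They also leave open how the number would respond to an amine or a carboxylic acid on the aromatic carbon that carries the methyl or chloro here, or to a longer chain on the sulfonyl sulfur.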